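Removing a Second Methoxy Group: Cytotoxicity Expected for Compound 4

A few compounds are considered here, and "the series" means these few. Any claim that something is new, unique, unknown or untested is made for them only; others in the source may bear on it.

Three compounds have been measured in a functional assay on MRC5 cells (Homo sapiens); on this read-out lower numbers stand for higher toxicity in this test and higher numbers for lower toxicity in this test:
Compound 1, `O=[N+]([O-])c1ccc(COC2=NS(=O)(=O)N(Cc3ccc([N+](=O)[O-])cc3)c3ccccc32)cc1`, gives 53000 nM.
Compound 2, `COc1ccc(CN2C(=O)c3ccccc3N(Cc3ccc(OC)cc3)S2(=O)=O)cc1`, gives 57000 nM.
Compound 3, `COc1ccc(CN2c3ccccc3C(=O)N(Cc3ccccc3)S2(=O)=O)cc1`, gives 61000 nM.

Compound 3 holds the highest of these three numbers, but its neighbours sit close by: compound 2 is within the scatter of it, and compound 1, the furthest, is also within the scatter. In this assay, then, the three measured compounds cannot be told apart.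

Compound 4, `O=C1c2ccccc2N(Cc2ccccc2)S(=O)(=O)N1Cc1ccccc1`, has not been measured yet. It arises from compound 3 by a single change: hydrogen in place of methoxy on an aromatic carbon. The same kind of change has been seen once already within this set, on the other benzyl arm of the shared core, where the step from compound 2 to compound 3 gave a 1.1-fold higher number from compound 2 to compound 3 (0.03 log units; within the scatter). Among the measured compounds shown here, that single precedent is the only step bearing on the new change, and it was flat.

On that basis, no step beyond the scatter is expected in this assay; the estimated step from compound 3 to compound 4 is a 1.0-fold lower number from compound 3 to compound 4 (0.01 log units; within the scatter). Compound 4 is therefore expected to give about 60000 nM, with a plausible range from 35000 nM to 100000 nM.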

Compound 4, half-maximal cytotoxic concentration: 66000 nM
Estimate against measurement, compound 4: 1.1-fold (0.04 log units) below; measured number inside the range.
By their numbers in this assay, from the lowest: compounds 1, 2, 3 and 4 (each within the scatter of the next).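

The change from 4-methoxybenzyl to benzyl can now be read on both benzyl arms of the shared core, not just one. In this assay, the second arm gives a 1.1-fold higher number from compound 3 to compound 4 (0.03 log units; within the scatter) and the first gave a 1.1-fold higher number from compound 2 to compound 3 (0.03 log units; within the scatter), so both steps lie within the scatter, and with no methoxy group left on either arm, compound 4 cannot be told apart from compound 3. At this place, para to a large group, methoxy and hydrogen therefore look interchangeable in this test, though no measurement on hand offers an explanation for that.

Going by these compounds, only methoxy and hydrogen are compared at this position, so it remains open whether an amine, a carboxylic acid or a longer chain such as butoxy on the same aromatic carbon would give a step beyond the scatter. These four compounds, each within the scatter of the next, also leave open whether any change on the benzyl arms can shift toxicity in this test, or whether the number depends on some other part of the molecule.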